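Swapping a Hydroxy for a Longer Protected Side Chain

The source may hold more compounds than are shown below. What is called first, only, known or untested is meant among the compounds shown, and "the series" means these compounds.

compound 1 `O=C(CN(c1ncnc2c1ncn2C1CCCCO1)C1CC1)N[C@@H](CO)C(=O)OCc1ccccc1` gives 32.2%
compound 2 `CSCC[C@H](NC(=O)CN(c1nc(Cl)nc2[nH]cnc12)C1CC1)C(=O)OCc1ccccc1` gives 44.6%

Both numbers come from a functional assay on the whole organism (Tail, strain ICR) with Mus musculus as the target, in the tail flick test, with a stated time of 90 min, at a dose of 25 umol/kg by the oral route; on this read-out lower numbers stand for a weaker effect and higher numbers for a stronger effect at the one dose given. Compound 1 stands lowest of the two; compound 2 sits higher by a margin beyond the scatter. Among the measured compounds shown here, no measured pair differs in only one place, so no single step can be traced. Compound 3 `CC(C)(C)OC(=O)NCCCC[C@H](NC(=O)CN(c1ncnc2c1ncn2C1CCCCO1)C1CC1)C(=O)OCc1ccccc1` is not yet measured and differs from compound 1 in this way: 3-((tert-butoxycarbonyl)amino)propyl in place of hydroxy on a saturated chain carbon, two bonds along the chain from an amide-type nitrogen and a carbonyl carbon. For the measured compounds named here, with no comparable step measured, only a modest change is expected, a number 5.8 percentage points higher from compound 1 to compound 3 (within the scatter). Compound 3 is estimated at 38%, within 15% to 62%.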

Compound 3, a percentage reported as activity, at one dose (the size of the read-out at that dose, not a potency): 32.9%
Estimate against measurement, compound 3: 5.1 percentage points above; low and high end bracket the measured number.
By their numbers in this assay, from the lowest: compounds 1 and 3 (each within the scatter of the next); then compound 2.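

In this assay the swap of hydroxy for 3-((tert-butoxycarbonyl)amino)propyl on a saturated chain carbon gives a number 0.7 percentage points higher from compound 1 to compound 3 (within the scatter) and so leaves the two compounds indistinguishable at the one dose given. This position therefore carries either the single hydroxy or the far longer protected chain without a separable difference in the read-out. Nothing available explains this result. On these data alone, whether a free amine at the end of that chain, or a carboxylic acid there, would read the same remains open.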